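Naphthalene Swap on the Saturated Ring Carbon: Compound 4

A few compounds are considered here, and "the series" means these few. Any claim that something is new, unique, unknown or untested is made for them only; others in the source may bear on it.

Measured so far:
compound 1 `N#CC1=C(N)OC(c2c[nH]c3ccccc23)=C(C#N)C1c1ccccc1F` gives 22800 nM;
compound 2 `N#CC1=C(N)OC(c2c[nH]c3ccccc23)=C(C#N)C1c1ccc2ccccc2c1` gives 15500 nM;
compound 3 `N#CC1=C(N)OC(c2c[nH]c3ccccc23)=C(C#N)C1c1ccc(F)cc1` gives 28000 nM, all in a functional assay on MCF7 cells (Homo sapiens) for cytotoxicity, read by MTT assay, with a stated time of 24 h; a lower number here means a stronger inhibitor of growth, a higher number a weaker inhibitor of growth.

Compound 3 has the highest of the three numbers in this assay, yet its gaps to compound 1 and compound 2 both lie within the scatter. Compound 4 `N#CC1=C(N)OC(c2c[nH]c3ccccc23)=C(C#N)C1c1cccc2ccccc12` differs from compound 3 in one place: naphthalen-1-yl in place of 4-fluorophenyl on a saturated ring carbon. The step that bears on it most is a 1.8-fold higher number from compound 2 to compound 3 (0.26 log units; within the scatter), a change between a naphthalenyl group and 4-fluorophenyl at the same carbon; the step of a 1.5-fold lower number from compound 1 to compound 2 (0.17 log units; within the scatter) also stayed within the scatter. Compound 4 is therefore expected to give a number close to compound 2, so that a 1.6-fold lower number from compound 3 to compound 4 (0.22 log units; within the scatter) is expected, not beyond the scatter. For compound 4 the estimate is 17000 nM, with a range from 8000 nM to 36000 nM.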

Compound 4, concentration for 50% growth inhibition: 18200 nM
The estimate for compound 4 lay 1.1-fold (0.03 log units) below the measured number; measured number inside the range.
By their numbers in this assay, from the lowest: compounds 2, 4, 1 and 3 (each within the scatter of the next).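

In this assay, changing naphthalen-2-yl to naphthalen-1-yl gives a 1.2-fold higher number from compound 2 to compound 4 (0.07 log units; within the scatter), so the two naphthalene attachments read alike at this saturated ring carbon. Replacing a fluorophenyl group with naphthalen-1-yl gives a 1.5-fold lower number from compound 3 to compound 4 (0.19 log units; within the scatter) and a 1.3-fold lower number from compound 1 to compound 4 (0.10 log units; within the scatter), so the larger group also changes little here. No measurement shown explains why these numbers stay so close.

Still open, as far as these compounds go, is whether a carboxylic acid, an amine or a longer carbon chain on this carbon would produce a step beyond the scatter.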